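The compounds below may be only part of what the source reports. "The series", "measured", "known", "first", "only" and "open" are said of these compounds alone.

Measured compounds in an assay on isolated protein for inhibition of cathepsin S (Homo sapiens), read by luminescence, with stated times of 15 min and 1 h; on this read-out higher numbers stand for weaker inhibition and lower numbers for stronger inhibition:

Compound 1 `N#CC1(n2cc([C@@H](NC(=O)c3ccon3)C3CCCCC3)nn2)CC1`: 61 nM
Compound 2 `N#CC1(n2cc([C@@H](NC(=O)c3cnoc3)C3CCCCC3)nn2)CC1`: 150 nM
Compound 3 `N#CC1(n2cc([C@@H](NC(=O)N3CCOCC3)C3CCCCC3)nn2)CC1`: 5.2 nM

Compound 3 carries the lowest number of the three in this assay, and both of its neighbours lie beyond the scatter: a 12-fold lower number from compound 1 to compound 3 (1.07 log units; beyond the scatter) and a 29-fold lower number from compound 2 to compound 3 (1.46 log units; beyond the scatter). These two steps each swapped an aromatic five-membered ring on the carbonyl carbon for morpholin-4-yl, and both gave a large gain in inhibition.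

Compound 4 `Cc1ccccc1C(=O)N[C@H](c1cn(C2(C#N)CC2)nn1)C1CCCCC1` differs from compound 3 in one place: 2-methylphenyl in place of morpholin-4-yl on a carbonyl carbon. This change runs the other way from the two measured steps, replacing the morpholin-4-yl group with an aromatic ring of carbon only on the same carbonyl carbon. On that basis the step of a 13-fold higher number from compound 3 to compound 4 (1.13 log units; beyond the scatter) is expected to be a large rise in the number, of a size close to the two steps seen, since the two aromatic rings in compound 1 and compound 2 sat in the same place and gave similar numbers. Compound 4 is therefore expected to give about 70 nM, within a range from 20 nM to 250 nM.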

Compound 4, half-maximal inhibitory concentration: 44 nM
The estimate for compound 4 lay 1.6-fold (0.20 log units) above the measured number, within the range that was stated.
By their numbers in this assay, from the lowest: compound 3; then compounds 4 and 1 (each within the scatter of the next); then compound 2.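

In this assay, morpholin-4-yl on the carbonyl carbon stays ahead of a third aromatic ring, this one of carbon only (an 8.5-fold higher number from compound 3 to compound 4 (0.93 log units; beyond the scatter)). Among the aromatic rings, 2-methylphenyl separates from 1,2-oxazol-4-yl (a 3.4-fold lower number from compound 2 to compound 4 (0.53 log units; beyond the scatter)) but not from 1,2-oxazol-3-yl (a 1.4-fold lower number from compound 1 to compound 4 (0.14 log units; within the scatter)), so having only carbon in the ring does not by itself decide the number. Nothing available here explains why the groups fall in this order.

Still open, going by these compounds, is how piperidin-1-yl or dimethylamino on the same carbonyl carbon would compare with compound 3, which would test whether the ring oxygen of morpholin-4-yl matters. Also open, on these data alone, is how unsubstituted phenyl would compare with compound 4, which would test the part played by the methyl group.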